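Swapping in a cyano group at the assay limit

The source may hold more compounds than are shown below. What is called first, only, known or untested is meant among the compounds shown, and "the series" means these compounds.

compound 1 `CC(C)[C@H]1C(O)=C(C2=NS(=O)(=O)c3c(O)cccc32)C(=O)N1Cc1ccccc1` gives > 33000 nM
compound 2 `CC(C)[C@H]1C(O)=C(C2=NS(=O)(=O)c3c(OCCC(N)=O)cccc32)C(=O)N1Cc1ccccc1` gives > 33000 nM
compound 3 `CC(C)[C@H]1C(O)=C(C2=NS(=O)(=O)c3c(OCC(=O)C(C)(C)C)cccc32)C(=O)N1Cc1ccccc1` gives > 33000 nM

All three compounds were tested in an ADME assay on Huh-7 cells (Homo sapiens) for cytotoxicity, with a stated time of 72 h (on this read-out higher numbers stand for lower toxicity in this test and lower numbers for higher toxicity in this test), and none returned a number. Compound 3 stands at > 33000 nM in this test, and that entry is a limit. It shares this position with compounds 1 and 2 (the limit of > 33000 nM in this assay, at which 3 of the 3 values shown sit).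

Compound 4 `CC(C)[C@H]1C(O)=C(C2=NS(=O)(=O)c3c(OCC#N)cccc32)C(=O)N1Cc1ccccc1` has not yet been measured. It carries cyano in place of (tert-butyl)carbonyl on a saturated chain carbon bound to an oxygen on an aromatic ring, so that ((tert-butyl)carbonyl)methoxy becomes cyanomethoxy.

Three measured changes on that oxygen bear on this one: first a step that the two limits leave unreadable from compound 1 to compound 2 then a step that the two limits leave unreadable from compound 1 to compound 3 and finally a step that the two limits leave unreadable from compound 2 to compound 3 and none of them has a size that can be read. They therefore give no direction, and no step beyond the scatter is expected in this assay for this change. The expectation rests on compound 3 with its limit of > 33000 nM as the starting point, and a further limit is the most likely report. The estimated change is a number no higher from compound 3 to compound 4 (the limit leaves the size open) and it is expected to carry no direction. The estimated value for compound 4 is 33000 nM with an expected range of 15000 nM to 60000 nM around it.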

Compound 4, half-maximal cytotoxic concentration: > 33000 nM
Compound 4 was reported as a limit; the forecaster's own chance of this, stated with the estimate: 85%; the middle value lies on the limit itself.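

In this assay compound 4 gives > 33000 nM, and that entry is a limit. Among the compounds shown here, no step between compound 4 and compound 1, compound 2 or compound 3 can be read, as all four sit together: the limit of > 33000 nM in this assay, at which 4 of the 4 values shown sit. The compounds shown leave open where any of their true values lies, and whether the groups on the oxygen differ at all in this test.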